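The compounds below may be only part of what the source reports. "The series", "measured", "known", "first", "only" and "open" are said of these compounds alone.

Compound 1 `O=S(=O)(Nc1ccc(F)c(Cl)c1)c1ccc(-c2cnc(C3CC3)o2)cc1` gives only a limit in a functional assay on cells (leukaemia cell line, Homo sapiens) for inhibition, read by sulforhodamine B assay, with a stated time of 48 h (on this read-out higher numbers stand for lower toxicity in this test and lower numbers for higher toxicity in this test), namely > 100000 nM. Compound 2 `O=S(=O)(Nc1ccc(Br)c(Cl)c1)c1ccc(-c2cnc(C3CC3)o2)cc1` likewise gives a limit in this assay, > 100000 nM. Compound 3 `Cc1ccc(NS(=O)(=O)c2ccc(-c3cnc(C4CC4)o3)cc2)cc1C` also sits at a limit in this assay, > 100000 nM. Compound 1 thus stands at the same limit as the other two, (the limit of > 100000 nM in this assay, at which 3 of the 3 values shown sit). The three steps among them, a step that the two limits leave unreadable from compound 1 to compound 2, a step that the two limits leave unreadable from compound 1 to compound 3 and a step that the two limits leave unreadable from compound 2 to compound 3, are of unreadable size. Compound 4 `Cc1ccc(Cl)c(NS(=O)(=O)c2ccc(-c3cnc(C4CC4)o3)cc2)c1` differs from compound 1 as follows: 2-chloro-5-methylphenyl in place of 3-chloro-4-fluorophenyl on a sulfonamide nitrogen. All three measured values are limits, so no measured step can be read on this change. The expectation for compound 4 is that it stays at the limit, a step that the limit leaves unreadable from compound 1 to compound 4 of no readable size. Compound 4 is therefore estimated at 150000 nM, within 50000 nM to 500000 nM.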

Compound 4, concentration lethal to 50% of the cells: > 100000 nM
Compound 4 was reported as a limit; the forecaster's own chance of this, stated with the estimate: 85%; the middle value does not contradict the limit.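

No step can be read among compound 1, compound 2, compound 3 and compound 4 in this assay: the limit of > 100000 nM in this assay, at which 4 of the 4 values shown sit. These compounds leave open whether any group on the sulfonamide nitrogen changes this read-out.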